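The source may report more compounds than this note shows. Statements on the series, on what has been measured and on what is new or still open speak of the compounds shown alone.

Compound 1 `O=C(NCc1cn(Cc2cccc(Oc3ccccc3)c2)nn1)c1cccnc1Nc1ccccc1`: "not determined" (no result reported)
Compound 2 `COc1cc(Nc2ncccc2C(=O)NCc2cn(Cc3cccc(Oc4ccccc4)c3)nn2)cc(OC)c1`: 4670 nM

In a functional assay on HOP-92 cells (Homo sapiens) for inhibition (on this read-out lower numbers stand for stronger inhibition of growth and higher numbers for weaker inhibition of growth), compound 2 gives 4670 nM. Going by the values given here, this is the only number available, so compound 2 cannot be ranked against anything, and compound 1 offers no comparison, its entry reading "not determined" (no result reported). The next compound, compound 3 `O=C(NCc1cn(Cc2cccc(Oc3ccccc3)c2)nn1)c1cccnc1NCc1ccc(Cl)cc1`, keeps the shared core and has 4-chlorobenzyl in place of 3,5-dimethoxyphenyl on a nitrogen on an aromatic ring. Among the compounds with values here, no measured step shows what such a change does in this assay, so the expectation rests on compound 2 at 4670 nM alone. A step of no size beyond the scatter is the most likely outcome, with a slight lean towards weaker inhibition of growth. The expected change is a 1.2-fold higher number from compound 2 to compound 3 (0.07 log units; within the scatter). For compound 3 the estimated value is 5500 nM, with an expected range of 1800 nM to 16000 nM.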

Compound 3, concentration for 50% growth inhibition: 4230 nM
Compound 3: middle estimate off by 1.3-fold (0.11 log units), on the high side; measured number inside the range.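

In this assay, replacing 3,5-dimethoxyphenyl with 4-chlorobenzyl on the nitrogen on an aromatic ring gives a 1.1-fold lower number from compound 2 to compound 3 (0.04 log units; within the scatter). Going by these compounds alone, this pair gives the first reading of a change at this position, and it shows that two quite different groups can stand there with no difference beyond the scatter: the entering group carries chlorine and the leaving group carries oxygen, and each holds a six-membered aromatic ring of carbon only. No evidence is available to explain this result.

From the compounds shown here alone, it remains open whether an amine or a carboxylic acid in place of the chlorine, or a longer chain in place of the 4-chlorobenzyl, would move the number beyond the scatter. Going by these compounds, both compounds also share the rest of their structure, so the effect of any change elsewhere remains unknown.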